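Lengthening a Side Chain in a Weak Cell Inhibitor

This account rests on a few compounds, and the source may have more. Where it says the series, first, only, none or still open, it means among the compounds named here.

Of the compounds shown here, two have so far been measured in a functional assay on A549 cells (Homo sapiens) for inhibition, read by MTT assay, with a stated time of 24 h; on this read-out higher numbers stand for weaker inhibition and lower numbers for stronger inhibition. Compound 1 `CCCc1cc2ccccc2nc1-c1cc(-c2ccccc2)no1` gives 52500 nM in this assay. Compound 2 `CCc1cc2ccccc2nc1-c1cc(-c2ccc(F)cc2)no1` reaches no number at all in this assay, only the limit > 100000 nM. For the measured compounds named here, that limit is the one noted as the limit of > 100000 nM in this assay, at which 1 of the 2 values shown sits, so compound 2 stands at the limit of the values shown, and no step can be measured between it and compound 1 beyond saying that compound 1 gives a number and compound 2 does not.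

Compound 3 `CCCc1cc2ccccc2nc1-c1cc(-c2ccc(F)cc2)no1` is yet to be measured. It differs from compound 2 by methyl in place of hydrogen on a saturated chain carbon, two bonds along the chain from an aromatic carbon. Going by the values given here, no measured pair shows this change, so no measured step tells its size. The expectation is a small step, possibly toward stronger inhibition, given that compound 1, which carries the longer chain, gives 52500 nM rather than a limit. For compound 3 the estimated step is an at least 1.4-fold lower number from compound 2 to compound 3 (0.15 log units; that floor lies within the scatter). Compound 3 is therefore expected to give about 70000 nM in this assay, within a range from 30000 nM to 150000 nM.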

Compound 3, half-maximal inhibitory concentration: 51300 nM
Compound 3: the middle estimate sits 1.4-fold (0.13 log units) above what was measured, within the range that was stated.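

The two earlier compounds differ in both the chain and the fluoro group, so neither change could be judged alone; compound 3 now separates them. In this assay, methyl in place of hydrogen on a saturated chain carbon, two bonds along the chain from an aromatic carbon, turns the ethyl chain into a propyl chain and gives an at least 1.9-fold lower number from compound 2 to compound 3 (0.28 log units; that floor lies within the scatter). Compound 2 has only a limit and not a number, so the full size of this step stays unknown: the limit of > 100000 nM in this assay, at which 1 of the 3 values shown sits.

With the propyl chain held constant, fluoro in place of hydrogen on an aromatic carbon gives a 1.0-fold lower number from compound 1 to compound 3 (0.01 log units; within the scatter), so this pair shows no measurable effect of the fluoro group. The compounds shown leave open whether a longer chain, such as butyl or pentyl, would lower the number further or whether the trend ends at propyl. They also do not show how a chain ending in an amine or a carboxylic acid would behave at this position, or whether chloro or methoxy in place of fluoro would matter.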